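The source may hold more compounds than are shown below. What is called first, only, known or untested is meant among the compounds shown, and "the series" means these compounds.

Among the measured compounds shown here, compound 2 `CCCCCCCCCCOP(=O)(O)OCCSC(=S)N1CCCCCC1` gives 43300 nM in a functional assay on MCF7 cells (Homo sapiens) for inhibition, read by MTT assay, with stated times of 18 h and 4 h (a higher number here means a weaker inhibitor, a lower number a stronger inhibitor), the only true number so far. Compound 1 `CCCCCCCCCCCCCCCCOP(=O)(O)OCCSC(=S)N1CCCCCC1` gives > 100000 nM, which is a limit of the assay. Compound 3 `CCCCCCCCCCOP(=O)(O)OCCSC(=S)N1CCN(C)CC1` has 4-methylpiperazin-1-yl in place of azepan-1-yl on a thiocarbonyl carbon. For the measured compounds named here, the single measured step, an at least 2.3-fold lower number from compound 1 to compound 2 (0.36 log units; beyond the scatter), changes the chain and leaves that group untouched, so it gives no guide to this change. In this assay the expected step, a 1.1-fold lower number from compound 2 to compound 3 (0.03 log units; within the scatter), therefore stays within the scatter, in neither direction. For compound 3 the estimate is 40000 nM, with an expected range of 15000 nM to 100000 nM.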

Compound 3, half-maximal inhibitory concentration: 99600 nM
For compound 3 the middle estimate is 2.5-fold (0.40 log units) below the measured one; measured number inside the range.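

On a thiocarbonyl carbon the ring matters in this assay: 4-methylpiperazin-1-yl in place of azepan-1-yl gives a 2.3-fold higher number from compound 2 to compound 3 (0.36 log units; beyond the scatter). This is the first step shown at this position, and it favours azepan-1-yl of these two groups with the chain of compound 2. The read-out ends at a limit not far above compound 3: the limit of > 100000 nM in this assay, at which 1 of the 3 values shown sits.

Ring size and the second ring nitrogen change together in this step, and the compounds shown do not separate them. On these data alone, how piperidin-1-yl or morpholin-4-yl would read on the same thiocarbonyl carbon remains open.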